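Moving the trifluoromethyl group: a large gain expected

The source may hold more compounds than are shown below. What is called first, only, known or untested is meant among the compounds shown, and "the series" means these compounds.

Three compounds sharing one core have been measured in a functional assay on HeLa cells (Homo sapiens) for inhibition; on this read-out lower numbers stand for stronger inhibition and higher numbers for weaker inhibition:

Compound 1, `Oc1cccc(-c2cc(-c3ccccc3F)cc(-c3cccc(O)c3)n2)c1`: 16000 nM
Compound 2, `Oc1cccc(-c2cc(-c3cccc(F)c3)cc(-c3cccc(O)c3)n2)c1`: 1400 nM
Compound 3, `Oc1cccc(-c2cc(-c3ccccc3C(F)(F)F)cc(-c3cccc(O)c3)n2)c1`: 15200 nM

Compound 3 stands second highest of the three numbers. Its nearest neighbour is compound 1, with a 1.1-fold lower number from compound 1 to compound 3 (0.02 log units; within the scatter), and its furthest is compound 2, with an 11-fold higher number from compound 2 to compound 3 (1.04 log units; beyond the scatter).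

Compound 4, `Oc1cccc(-c2cc(-c3cccc(C(F)(F)F)c3)cc(-c3cccc(O)c3)n2)c1`, differs from compound 3 by 3-(trifluoromethyl)phenyl in place of 2-(trifluoromethyl)phenyl on an aromatic carbon.

Among the measured compounds shown here, the one measured step that mirrors this change is the move of fluoro from the 2-position to the 3-position of the phenyl, which gave an 11-fold lower number from compound 1 to compound 2 (1.06 log units; beyond the scatter). Since the trifluoromethyl analogue compound 3 sits with compound 1 within the scatter, as a 1.1-fold lower number from compound 1 to compound 3 (0.02 log units; within the scatter) shows, the same shift of the trifluoromethyl group is expected to bring a comparable large drop in this assay. The step is therefore estimated as an 8.4-fold lower number from compound 3 to compound 4 (0.93 log units; beyond the scatter). For the measured compounds named here, compound 4 is expected to give 1800 nM in this assay, within a range from 600 nM to 6000 nM, since only one matching step, an 11-fold lower number from compound 1 to compound 2 (1.06 log units; beyond the scatter), supports the estimate.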

Compound 4, half-maximal inhibitory concentration: 12700 nM
Beside the measured number, compound 4's estimate is 7.1-fold (0.85 log units) below it; the measured number lies above the stated range.
By their numbers in this assay, from the lowest: compound 2; then compounds 4, 3 and 1 (each within the scatter of the next).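

In this assay, exchanging 2-(trifluoromethyl)phenyl for 3-(trifluoromethyl)phenyl gives a 1.2-fold lower number from compound 3 to compound 4 (0.08 log units; within the scatter), so the two placements of trifluoromethyl on this phenyl are not told apart, unlike the two placements of fluoro in the earlier pair. The 3-(trifluoromethyl)phenyl group also stays within the scatter of the 2-fluorophenyl group, with a 1.3-fold lower number from compound 1 to compound 4 (0.10 log units; within the scatter), whereas trifluoromethyl in place of fluoro gives a 9.1-fold higher number from compound 2 to compound 4 (0.96 log units; beyond the scatter), which leaves compound 2 alone with the lowest number of the four. The effect of exchanging fluoro for trifluoromethyl at this position therefore depends on where the group sits on the phenyl, and the two readings of that exchange do not agree: the same change on two cores in this assay, a 1.1-fold lower number (0.02 log units; within the scatter) from compound 1 to compound 3 and a 9.1-fold higher number (0.96 log units; beyond the scatter) from compound 2 to compound 4, 9.5-fold (0.98 log units) apart, beyond the scatter of two such steps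

The compounds shown leave open whether the lower number of compound 2 is particular to fluoro or would also appear with a chloro, methoxy or nitrile group in the same place on the phenyl. They also leave open whether an amine or a carboxylic acid on this phenyl would follow compound 2 or the other three compounds.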